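A few compounds are considered here, and "the series" means these few. Any claim that something is new, unique, unknown or untested is made for them only; others in the source may bear on it.

Of the compounds shown here, three built on one shared core have been measured in an assay for binding affinity to histamine H2 receptor (Homo sapiens); a higher number here means a weaker inhibitor, a lower number a stronger inhibitor. Compound 1 `CNCC(=O)N1CCN(CCCOc2ccc(C(=O)C3CC3)cc2)CC1` gives 79400 nM. Compound 2 `CC(C)N[C@H](C)C(=O)N1CCN(CCCOc2ccc(C(=O)C3CC3)cc2)CC1` gives 50100 nM, and compound 3 `CN[C@@H](C(=O)N1CCN(CCCOc2ccc(C(=O)C3CC3)cc2)CC1)C(C)C` gives 49000 nM. The steps of a 1.6-fold lower number from compound 1 to compound 2 (0.20 log units; within the scatter) and a 1.6-fold lower number from compound 1 to compound 3 (0.21 log units; within the scatter) stayed within the scatter, as did a 1.0-fold lower number from compound 2 to compound 3 (0.01 log units; within the scatter), so compound 3 holds the lowest of the three numbers only by margins that the assay cannot separate. Compound 4 `N[C@H](CC1CCCCC1)C(=O)N1CCN(CCCOc2ccc(C(=O)C3CC3)cc2)CC1` carries 1-amino-2-cyclohexylethyl in place of 2-methyl-1-(methylamino)propyl on a carbonyl carbon. Within the data shown here, none of the measured steps brings in a ring or removes the methyl from the amine nitrogen at that place, so the earlier small steps bear on this change only loosely; the expected step is a 1.0-fold higher number from compound 3 to compound 4 (0.01 log units; within the scatter), nothing beyond the scatter. Compound 4 is estimated at 50000 nM, with a range from 15000 nM to 160000 nM.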

Compound 4, inhibition constant: 20400 nM
Beside the measured number, compound 4's estimate is 2.5-fold (0.39 log units) above it, and the stated range covers the measured number.
By their numbers in this assay, from the lowest: compound 4; then compounds 3, 2 and 1 (each within the scatter of the next).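

Among these compounds, the steps of a 2.4-fold lower number from compound 3 to compound 4 (0.38 log units; beyond the scatter) and a 2.5-fold lower number from compound 2 to compound 4 (0.39 log units; beyond the scatter) and a 3.9-fold lower number from compound 1 to compound 4 (0.59 log units; beyond the scatter) are the first at this place to lie beyond the scatter, though all are modest. Among the compounds shown here, they show that the number can move with the group on this carbonyl carbon, which the earlier compounds, all within the scatter of one another, did not show. Nothing given here offers a reason for this shift.

Compound 4 brings in the cyclohexyl ring and a free amine together, so the two changes cannot be told apart. As far as these compounds go, how a phenyl ring or a longer alkyl chain would read at this place stays open.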